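A few compounds are considered here, and "the series" means these few. Any claim that something is new, unique, unknown or untested is made for them only; others in the source may bear on it.

Working notes on the series in a functional assay on KB cells (Homo sapiens) for cytotoxicity; on this read-out higher numbers stand for an effect only at larger amounts of compound and lower numbers for an effect already at smaller amounts.

Going by the values given here, compound 1 `CS(=O)(=O)Oc1cc(-c2ccccc2)nc2ccccc12` gives 2.8 ug/mL in this assay, the highest of the three numbers measured so far. Compound 2 `COc1ccc2nc(-c3ccccc3)cc(O)c2c1` gives 0.08 ug/mL, and compound 3 `Oc1cc(-c2ccccc2)nc2ccc(Cl)cc12` gives 0.49 ug/mL; both of these lie lower than compound 1, in each case beyond the scatter, with compound 2 the further away.

Among the compounds with values here, only one step between measured compounds is known, a 6.1-fold higher number from compound 2 to compound 3 (0.79 log units; beyond the scatter). That change sits on an aromatic carbon of the core and leaves the oxygen untouched, so it does not bear on the step considered here.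

Compound 4 `CCCOc1cc(-c2ccccc2)nc2ccccc12` differs from compound 1 as follows: propyl in place of methylsulfonyl on an oxygen on an aromatic ring

Within the data shown here, no measured pair shows (methylsulfonyl)oxy against propoxy, and compounds 2 and 3 carry a hydroxyl on that oxygen rather than either group, so their lower numbers give no measured step for this change. With nothing in the measured steps pointing in either direction, the step from compound 1 to compound 4 is expected to stay within the scatter, as a 1.4-fold lower number from compound 1 to compound 4 (0.15 log units; within the scatter), with a wide range. Compound 4 is therefore estimated at 2 ug/mL, within 0.4 ug/mL to 10 ug/mL in this assay.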

Compound 4, half-maximal effective concentration: 4.5 ug/mL
Estimate against measurement, compound 4: 2.3-fold (0.35 log units) below; the measured number falls inside the stated range.
By their numbers in this assay, from the lowest: compound 2; then compound 3; then compounds 1 and 4 (each within the scatter of the next).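

Going by these compounds alone, at this oxygen on an aromatic ring, the first measured step in this assay is propyl in place of methylsulfonyl, and it gives a 1.6-fold higher number from compound 1 to compound 4 (0.21 log units; within the scatter) with the result remaining within the scatter. The change therefore replaces a group of 4 heavy atoms with 2 hydrogen-bond acceptors by one of 3 carbon atoms with no hydrogen-bond acceptors, without a separation of compound 1 from compound 4 on this read-out. For these two groups, the measured step gives no sign that the choice between (methylsulfonyl)oxy and propoxy moves the number beyond the scatter, and no measurement offered here gives a reason for that result.

Going by these compounds, compounds 2 and 3 carry a hydroxyl on this oxygen and also differ from compound 1 on the core, so it remains open how much of their separation from compound 1 belongs to this oxygen and how much to the other change. Also open, on these data alone, is whether the same flat response would hold for a longer chain such as hexyl, for a chain ending in an amine or a carboxylic acid, or for a benzyl group on this oxygen, since two groups define only a narrow part of what this place can carry.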